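The compounds below may be only part of what the source reports. "The series", "measured", "known", "first", "only" and "open" are said of these compounds alone.

Measured so far in a functional assay on Huh-7 cells (Homo sapiens) for antiproliferative activity, read by sulforhodamine B assay, with a stated time of 72 h; a higher number here means a weaker inhibitor, a lower number a stronger inhibitor:
compound 1 `FC(F)(F)c1ccc(CN2CCN(Cc3cc(-c4ccc(OCc5cccc(Cl)c5)cc4)on3)CC2)cc1` gives 200 nM
compound 2 `COc1ccc(COc2ccc(-c3cc(CN4CCN(Cc5ccc(C(F)(F)F)cc5)CC4)no3)cc2)cc1` gives 3200 nM

For the measured compounds named here, compound 2 holds the highest of the two numbers; the only neighbour is compound 1, with the step of a 16-fold higher number from compound 1 to compound 2 (1.20 log units; beyond the scatter). Compound 3 `COc1cc(COc2ccc(-c3cc(CN4CCN(Cc5ccc(C(F)(F)F)cc5)CC4)no3)cc2)cc(OC)c1` is not yet measured. It differs from compound 2 by 3,5-dimethoxyphenyl in place of 4-methoxyphenyl on a saturated chain carbon bound to an oxygen on an aromatic ring. Going by the values given here, no measured step covers a change of this kind; the one step known, from compound 1 to compound 2, concerns a different change at the same place and so gives only an indirect bearing. The expectation is therefore a step of a 1.4-fold higher number from compound 2 to compound 3 (0.15 log units; within the scatter), not clearly beyond the scatter. Compound 3 is expected to give 4500 nM, within 1500 nM to 14000 nM.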

Compound 3, half-maximal inhibitory concentration: 1500 nM
The estimate for compound 3 lay 3.0-fold (0.48 log units) above the measured number, and the stated range covers the measured number.
By their numbers in this assay, from the lowest: compound 1; then compound 3; then compound 2.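

In this assay, 3,5-dimethoxyphenyl in place of 4-methoxyphenyl on a saturated chain carbon bound to an oxygen on an aromatic ring gives a 2.1-fold lower number from compound 2 to compound 3 (0.33 log units; beyond the scatter) as a modest step, so this place responds to changes among methoxy-bearing rings too. 3-Chlorophenyl still holds the lowest number, with a 7.5-fold higher number from compound 1 to compound 3 (0.88 log units; beyond the scatter) as the step, so neither methoxy-bearing ring matches it. Nothing at hand accounts for either step.

Whether the second methoxy or the altered methoxy placement drives the lower number stays unresolved. As far as these compounds go, how a nitrile, an amine or a carboxylic acid on this ring would read also remains open.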